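The source may hold more compounds than are shown below. What is called first, only, known or untested is meant among the compounds shown, and "the series" means these compounds.

Measured so far in a functional assay on cells for antagonist activity at C-X-C chemokine receptor type 4 (Homo sapiens), read by fluorescence and calcium flux, with stated times of 25 min and 90 s; a higher number here means a weaker inhibitor, a lower number a stronger inhibitor:
- compound 1 `c1cncc(CN(CCCCN(C[C@H]2Cc3ccccc3CN2)[C@H]2CCCc3cccnc32)Cc2cccnc2)c1`: 471 nM
- compound 2 `c1ccc2c(c1)CN[C@@H](CN(CCCCN(Cc1ccncc1)Cc1ccncc1)[C@H]1CCCc3cccnc31)C2`: 832 nM
- compound 3 `c1ccc(CN(CCCCN(C[C@H]2Cc3ccccc3CN2)[C@H]2CCCc3cccnc32)Cc2ccccc2)cc1`: > 16700 nM, a limit of the assay, not a number

Compound 1 holds the lowest of the two numbers in this assay; compound 2 sits within the scatter of it, so no order between the two is claimed. For compound 3 the assay gives only a limit, (the limit of > 16700 nM in this assay, at which 1 of the 3 values shown sits). Among the compounds with values here, no pair of measured compounds here differs in a single place, so no measured step is available to set a scale for what follows.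

Compound 4 `c1cncc(CNCCCCN(C[C@H]2Cc3ccccc3CN2)[C@H]2CCCc3cccnc32)c1` departs from compound 1 by hydrogen in place of (pyridin-3-yl)methyl on an amine nitrogen. The one remaining amine substituent on that side of the chain is kept. How far this change moves the number in this assay is not shown by any measured pair, so the direction and size rest on expectation alone. The step from compound 1 to compound 4 is expected at a 3.2-fold higher number from compound 1 to compound 4 (0.50 log units; beyond the scatter), towards a weaker inhibitor, beyond the scatter but short of the limit of the assay. Compound 4 is thus estimated at 1500 nM in this assay, with a range from 500 nM to 5000 nM.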

Compound 4, half-maximal inhibitory concentration: 15.3 nM
The estimate for compound 4 lay 98-fold (1.99 log units) above the measured number; the whole stated range lies above it.
By their numbers in this assay, from the lowest: compound 4; then compounds 1 and 2 (each within the scatter of the next). At a limit, above all of these: compound 3.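

Hydrogen in place of (pyridin-3-yl)methyl on this amine nitrogen gives a 31-fold lower number from compound 1 to compound 4 (1.49 log units; beyond the scatter) in this assay, the first single-place comparison in the series and a large step towards a stronger inhibitor. This position therefore responds strongly to what it carries, and a single (pyridin-3-yl)methyl on this nitrogen is enough for compound 4 to reach 15.3 nM. Nothing measured here gives a cause for this step.

From the compounds shown here alone, it remains open what a primary amine would give at this end of the chain in place of the remaining (pyridin-3-yl)methyl, and whether a benzyl group could take that place. Also open, going by these compounds, is how a longer chain between the two amine nitrogens would read in this assay.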